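Benzyl arm of compound 1: hydroxymethyl to 3-hydroxypropoxy

The source may hold more compounds than are shown below. What is called first, only, known or untested is meant among the compounds shown, and "the series" means these compounds.

Measured so far in an assay for inhibition of Amine oxidase [flavin-containing] B (Homo sapiens), read by fluorescence, using microsomes, with a stated time of 30 min; a higher number here means a weaker inhibitor, a lower number a stronger inhibitor:
- compound 1 `Cc1c(C)c2ccc(OCC3CCN(Cc4cccc(CO)c4)CC3)cc2oc1=O`: compound 1 gives 76 nM
- compound 2 `Cc1cc(=O)oc2cc(OCC3CCN(Cc4cccc(CO)c4)CC3)ccc12`: compound 2 gives 480 nM
- compound 3 `Cc1cc2ccc(OCC3CCN(Cc4cccc(CO)c4)CC3)cc2oc1=O`: compound 3 gives 1100 nM

Compound 1 holds the lowest number of the three. The two measured steps both leave the piperidine-linked benzyl arm untouched and remove a methyl from the shared core of compound 1: a 6.3-fold higher number from compound 1 to compound 2 (0.80 log units; beyond the scatter) and a 14-fold higher number from compound 1 to compound 3 (1.16 log units; beyond the scatter). Both run upward and both lie beyond the scatter, so compound 1 stands clearly apart at the low end.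

Compound 4 `Cc1c(C)c2ccc(OCC3CCN(Cc4cccc(OCCCO)c4)CC3)cc2oc1=O` keeps the core of compound 1 unchanged and alters only the benzyl arm: 3-hydroxypropoxy in place of hydroxymethyl on an aromatic carbon. Neither measured step bears on this position; the steps from compound 1 to compound 2 and to compound 3 concern the core alone and give no reading on the benzyl substituent. The hydroxyl-bearing group is replaced by a longer hydroxyl-bearing chain, with the donor count unchanged and one acceptor more, as the difference above records. Going by the values given here, with no measured step touching this arm, the expectation is a step within the scatter, and the estimated step is a 1.4-fold higher number from compound 1 to compound 4 (0.16 log units; within the scatter). For compound 4 the expected value in this assay is 110 nM, with a range from 35 nM to 400 nM.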

Compound 4, half-maximal inhibitory concentration: 780 nM
Compound 4: the middle estimate sits 7.1-fold (0.85 log units) below what was measured; measured number outside the range, above it.
By their numbers in this assay, from the lowest: compound 1; then compounds 2, 4 and 3 (each within the scatter of the next, the first and the last beyond it).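

In this assay the benzyl arm is no silent position: a 10-fold higher number from compound 1 to compound 4 (1.01 log units; beyond the scatter) is a large step beyond the scatter, in the same size class as a 14-fold higher number from compound 1 to compound 3 (1.16 log units; beyond the scatter) and larger in its label than the modest 6.3-fold higher number from compound 1 to compound 2 (0.80 log units; beyond the scatter) on the core side. Both hydroxymethyl and 3-hydroxypropoxy carry a hydroxyl and are counted with one hydrogen-bond donor and no net charge, so these shared features alone do not preserve the number of compound 1 at 76 nM in this series. No measurement bears on the source of the step, and the longer chain and the added oxygen cannot be separated as contributors.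

Open, on these data alone, is whether a shorter 2-hydroxyethoxy chain, a plain methoxy group, an aminomethyl group or a carboxylic acid on this arm would stay close to compound 1 or move as far as compound 4. Also open, as far as these compounds go, is whether 3-hydroxypropoxy would produce a step of similar size on the cores of compound 2 and compound 3, which carry one methyl fewer.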